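The source may report more compounds than this note shows. Statements on the series, on what has been measured and on what is new or still open speak of the compounds shown alone.

In a functional assay on PC-3 cells (Homo sapiens) for cytotoxicity, read by MTT assay, with a stated time of 72 h (on this read-out higher numbers stand for weaker inhibition and lower numbers for stronger inhibition), compound 1 `O=C(Nc1ccc(Oc2ccnc3[nH]ccc23)c(F)c1)c1nn(-c2ccc(Br)cc2)ccc1=O` gives 40800 nM. Compound 2 `O=C(Nc1ccc(Oc2ccnc3[nH]ccc23)c(F)c1)c1nn(-c2ccc(Br)cc2F)ccc1=O` differs from it by fluoro in place of hydrogen on an aromatic carbon and gives 8800 nM; the step is a 4.6-fold lower number from compound 1 to compound 2 (0.67 log units; beyond the scatter). Compound 3 `Cc1cc(=O)n(-c2ccc(F)cc2)nc1C(=O)Nc1ccc(Oc2ncnc3[nH]ccc23)cc1` carries a different core; the difference between the two cores is not broken down here. For compound 3 this assay reports only a limit, > 60000 nM, and that value sits at the limit of > 60000 nM in this assay, at which 1 of the 3 values shown sits. Compound 4 `Cc1cc(=O)n(-c2ccc(F)cc2)nc1C(=O)Nc1ccc(Oc2ncnc3[nH]ccc23)c(F)c1` is still to be measured in this assay and differs from compound 3 by fluoro in place of hydrogen on an aromatic carbon. This is the same kind of change as that in compound 2, though there the place was meta to a bromo group (1 heavy atom), here meta to a large group. Compound 4 is expected to give 30000 nM. The expected range for compound 4 runs from 10000 nM to 90000 nM. The expected step, an at least 2.0-fold lower number from compound 3 to compound 4 (0.30 log units; that floor lies within the scatter), rests on a 4.6-fold lower number from compound 1 to compound 2 (0.67 log units; beyond the scatter) and on compound 3 standing at a limit, so it is loosely held.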

Compound 4, half-maximal inhibitory concentration: 17300 nM
Estimate against measurement, compound 4: 1.7-fold (0.24 log units) above, within the range that was stated.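

In this assay, fluoro in place of hydrogen on an aromatic carbon again goes with a lower number on a second core, an at least 3.4-fold lower number from compound 3 to compound 4 (0.54 log units; beyond the scatter). Set beside the earlier step, the comparison reads: the same change on two cores in this assay, a 4.6-fold lower number (0.67 log units; beyond the scatter) from compound 1 to compound 2 and an at least 3.4-fold lower number (0.54 log units; beyond the scatter) from compound 3 to compound 4; the limit leaves it open whether they differ. The direction of the change therefore holds on these two cores, but the size of the step on the core of compound 3 stays unfixed, since compound 3 is known only through a limit: the limit of > 60000 nM in this assay, at which 1 of the 4 values shown sits.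

From the compounds shown here alone, whether a chloro or methoxy group on the same carbon would go the same way as fluoro remains open. Two pairs also leave open whether the change would carry to any further core in this series.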